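A few compounds are considered here, and "the series" means these few. Any claim that something is new, unique, unknown or untested is made for them only; others in the source may bear on it.

Three compounds have so far been measured in an assay on CHO cells for displacement of a labelled ligand from adenosine receptor A1 (Homo sapiens), read by scintillation counting, tested at 10 uM; a lower number here means less inhibition, a higher number more inhibition at the concentration tested (going by the name of the read-out):

compound 1, `COc1cccc(-c2sc(N)c(C(=O)c3ccc(Cl)cc3)c2CC(C)(C)C)c1`, giving 1%
compound 2, `Cc1cccc(-c2sc(N)c(C(=O)c3ccc(Cl)cc3)c2CC(C)(C)C)c1`, giving 1%
compound 3, `CC(C)c1ccc(-c2sc(N)c(C(=O)c3ccc(Cl)cc3)c2CC(C)(C)C)cc1`, giving 1%

All three share one core and differ only in the aryl group carried on that core. Compound 3 stands level with the other two: no change at the digits printed from compound 1 to compound 3 (within the scatter) and no change at the digits printed from compound 2 to compound 3 (within the scatter), and the pair of them is itself flat, no change at the digits printed from compound 1 to compound 2 (within the scatter). None of the substitution patterns tried on that ring has lifted the read-out in this assay above the level of the others.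

Compound 4, `CC(C)(C)Cc1c(-c2ccccc2)sc(N)c1C(=O)c1ccc(Cl)cc1`, is the next member of this series and carries the bare parent ring in that position. Its difference from compound 3 is hydrogen in place of isopropyl on an aromatic carbon.

Among the compounds with values here, the steps that bear on this change are those from compound 1 and compound 2 to compound 3, in which the group on that same ring was exchanged without any movement beyond the scatter. Exchanging isopropyl for hydrogen is a smaller change than either of those, so no step beyond the scatter is expected in this assay; the expected step is no change at the digits printed from compound 3 to compound 4 (within the scatter). Compound 4 is therefore estimated at 1%, within a range from -6% to 12%.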

Compound 4, a percentage reported as inhibition, at one concentration (the size of the read-out at that concentration, not a potency): 1%
Compound 4: middle estimate and measured number agree at the digits printed; low and high end bracket the measured number.
By their numbers in this assay, from the lowest: compounds 1, 2, 3 and 4 (each within the scatter of the next).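

Within the data shown here, with the substituent gone altogether, compound 4 gives 1% in this assay and supplies what the earlier compounds lacked, a reference with only hydrogen on that ring: the read is no change at the digits printed from compound 3 to compound 4 (within the scatter) for loss of isopropyl, no change at the digits printed from compound 2 to compound 4 (within the scatter) for loss of methyl and no change at the digits printed from compound 1 to compound 4 (within the scatter) for loss of methoxy. The earlier steps compared substituted rings only with one another, whereas these show that none of the three groups can be told apart from hydrogen in this assay, whichever place on the ring it occupies among those shown. Nothing available here offers an explanation for this flat result.

As far as these compounds go, all four compounds keep the same 4-chlorobenzoyl-bearing shared core and carry only hydrogen or small carbon or methoxy groups on the ring, so it remains open whether an amine, a carboxylic acid or a longer chain there would move the read-out. Among these compounds, equally open is whether any change elsewhere on the shared core would do so, and with no member of this set standing apart, the set cannot show what this position contributes in a compound that registers clear inhibition.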